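Chloro to Amino on the Shared Core: an Expected Shift

The source may hold more compounds than are shown below. What is called first, only, known or untested is meant among the compounds shown, and "the series" means these compounds.

Compound 1 `COc1ccc(CN(CCN(C)C)c2ccc(Cl)cc2)cc1` and compound 2 `COc1ccc(CN(CCN(C)C)c2ccc(N)cc2)cc1` differ by amino in place of chloro on an aromatic carbon. In a physicochemical assay for acid dissociation, compound 1 gives 9.6, and compound 2 gives 9.8, a step of a number 0.20 log units higher from compound 1 to compound 2 (within the scatter). Compound 3 `COc1ccc(CN(CCN(C)C)c2ccc(Cl)cn2)cc1` differs from compound 1 by 5-chloropyridin-2-yl in place of 4-chlorophenyl on an amine nitrogen; in this assay compound 3 gives 9.5, with steps of a number 0.10 log units lower from compound 1 to compound 3 (within the scatter) and a number 0.30 log units lower from compound 2 to compound 3 (within the scatter). Compound 4 `COc1ccc(CN(CCN(C)C)c2ccc(N)cn2)cc1` is not yet measured and differs from compound 3 by amino in place of chloro on an aromatic carbon. Around the place the ring is of carbon only in the earlier pair but a six-membered aromatic ring with one nitrogen, two atoms from the ring nitrogen, here, so this is the same kind of change rather than the same change. Because the earlier step was a number 0.20 log units higher from compound 1 to compound 2 (within the scatter), a step of a number 0.20 log units higher from compound 3 to compound 4 (within the scatter) is expected. Compound 4 is estimated at 9.7, expected between 9.4 and 10.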

Compound 4, acid dissociation constant: 9.4
Beside the measured number, compound 4's estimate is 0.30 log units above it; low and high end bracket the measured number.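

In this assay amino in place of chloro gives a number 0.10 log units lower from compound 3 to compound 4 (within the scatter) and, on the core of compound 1, gave a number 0.20 log units higher from compound 1 to compound 2 (within the scatter); both steps lie within the scatter, so their opposite directions cannot be read as a real difference between the cores, and neither a higher nor a lower read-out is shown for this change on either core. Of the steps that change the ring on the amine nitrogen, a number 0.40 log units lower from compound 2 to compound 4 (beyond the scatter) is modest and a number 0.20 log units lower from compound 1 to compound 4 (within the scatter) is not beyond the scatter. Nothing available explains any of these steps.

Only amino and chloro are compared at this place on the two cores. As far as these compounds go, whether a hydroxyl or a carboxylic acid there would give steps beyond the scatter, and alike on both cores, remains open.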